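The source may hold more compounds than are shown below. What is called first, only, known or untested is meant among the compounds shown, and "the series" means these compounds.

Compound 1 `CCc1nc(-c2ccc(OC)cc2C(F)(F)F)c(CC)nc1NC(CC)CC`, compound 2 `CCc1nc(-c2ccc(Cl)cc2Cl)c(OC)nc1NC(CC)CC` and compound 3 `CCc1nc(-c2ccc(Cl)cc2Cl)c(CC)nc1NC(CC)CC` were each tested in an in vitro ADME assay on microsomes (Homo sapiens) for metabolic stability; on this read-out higher numbers stand for a longer-lived compound and lower numbers for a shorter-lived compound. Compound 1 gives 0.2 h, compound 2 gives 0.7 h, and compound 3 gives 0.283 h. One change, (methoxy in place of ethyl on an aromatic carbon), made a 2.5-fold higher number from compound 3 to compound 2 (0.39 log units; beyond the scatter). Compound 4 `CCc1nc(NC(CC)CC)c(OC)nc1-c1ccc(OC)cc1C(F)(F)F` carries the same kind of change on the core of compound 1: methoxy in place of ethyl on an aromatic carbon. The surroundings of the place are not identical: in compound 3 the carbon is ortho to a 2,4-dichlorophenyl group and meta to a (pentan-3-yl)amino group, whereas in compound 1 it is ortho to a (pentan-3-yl)amino group and meta to a large group. How the cores of compound 1 and compound 3 differ is not broken down here. The expectation rests on compound 1 at 0.2 h and on the modest size of a 2.5-fold higher number from compound 3 to compound 2 (0.39 log units; beyond the scatter). Compound 4 is therefore expected to move by a 2.5-fold higher number from compound 1 to compound 4 (0.40 log units; beyond the scatter) in this assay. The estimate for compound 4 is 0.5 h, probably between 0.25 h and 1 h.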

Compound 4, half-life: 2 h
Beside the measured number, compound 4's estimate is 4.0-fold (0.60 log units) below it; measured number outside the range, above it.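

In this assay, methoxy in place of ethyl gives a 10-fold higher number from compound 1 to compound 4 (1.00 log units; beyond the scatter), so the number rises on the core of compound 1, as it did on the core of compound 3. The direction carries over between these two pairs, but the size does not: the same change on two cores in this assay, a 2.5-fold higher number (0.39 log units; beyond the scatter) from compound 3 to compound 2 and a 10-fold higher number (1.00 log units; beyond the scatter) from compound 1 to compound 4, 4.0-fold (0.61 log units) apart, beyond the scatter of two such steps. These pairs do not show which difference between the two cores sets the sizes apart, and two pairs make no rule for other cores in this series.

The compounds shown leave open whether a longer chain, such as propoxy, or an amine in the same place would raise the number too. They also leave open whether methoxy would give a similar step with another amine in place of the (pentan-3-yl)amino group.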